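The source may hold more compounds than are shown below. What is called first, only, known or untested is meant among the compounds shown, and "the series" means these compounds.

Compound 2 `CN(C)/[N+]([O-])=N/Oc1cc(O/N=[N+](\[O-])N2CCCCC2)c([N+](=O)[O-])cc1[N+](=O)[O-]` has been tested in a functional assay on HL-60 cells (Homo sapiens) for antiproliferative activity, read by MTT assay, with a stated time of 72 h (on this read-out lower numbers stand for stronger inhibition of growth and higher numbers for weaker inhibition of growth), where compound 2 gives 4900 nM. That is the higher of the two numbers recorded so far; the other comes from compound 1 `CCOC(=O)N1CCN(/[N+]([O-])=N/Oc2cc(O/N=[N+](\[O-])N(C)C)c([N+](=O)[O-])cc2[N+](=O)[O-])CC1`, which in this assay gives 2000 nM. Among the measured compounds shown here, the single step between measured compounds, a 2.5-fold higher number from compound 1 to compound 2 (0.39 log units; beyond the scatter), exchanged one whole ring for another. Compound 3 `CC1CCCCN1/[N+]([O-])=N/Oc1cc(O/N=[N+](\[O-])N(C)C)c([N+](=O)[O-])cc1[N+](=O)[O-]` is not yet measured. It differs from compound 2 in one place: methyl in place of hydrogen on a saturated ring carbon. For the measured compounds named here, no measured step tries this kind of change; the step from compound 1 to compound 2 swapped an entire ring and was only modest even so. With nothing pointing to a direction, the expected change in this assay is small, most likely none beyond the scatter. Compound 3 is therefore expected to give about 5000 nM in this assay, with a range from 2500 nM to 10000 nM. That amounts to an expected step of a 1.0-fold higher number from compound 2 to compound 3 (0.01 log units; within the scatter).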

Compound 3, concentration for total growth inhibition: 4900 nM
Compound 3: the middle estimate sits 1.0-fold (0.01 log units) above what was measured; the range from low to high includes it.
By their numbers in this assay, from the lowest: compound 1; then compounds 2 and 3 (each within the scatter of the next).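

Methyl in place of hydrogen on a saturated ring carbon, next to the ring nitrogen, is a far smaller change than the whole-ring swap tried earlier, and in this assay it gives no change at the digits printed from compound 2 to compound 3 (within the scatter) in this series. At this one position, then, 2-methylpiperidin-1-yl and piperidin-1-yl cannot be told apart on growth inhibition. The gap to the 4-(ethoxycarbonyl)piperazin-1-yl ring stays as large as before, with a 2.5-fold higher number from compound 1 to compound 3 (0.39 log units; beyond the scatter), and no measurement at hand explains either result.

Only a single methyl is shown here, so it remains open whether an ethyl group or an amine on the same ring carbon would also leave the number in place. Also open, as far as these compounds go, is whether the lower number of compound 1 goes with the ethoxycarbonyl group or with the ring that carries it.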